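Swapping the Aryl Group: Expected Permeability of Compound 3

A few compounds are considered here, and "the series" means these few. Any claim that something is new, unique, unknown or untested is made for them only; others in the source may bear on it.

Measured so far:
Compound 1, `CCCS(=O)(=O)Nc1ccc(F)c(C(=O)Nc2cnc3[nH]c(-c4ccc(Br)cc4)nc3c2)c1F`: in an ADME assay on Caco-2 cells (Homo sapiens) for permeability, in the apical to basolateral direction (a higher number here means that the compound crosses the layer faster, a lower number that the compound crosses the layer more slowly), compound 1 gives 1.3 10^-6 cm/s.
Compound 2, `CCCS(=O)(=O)Nc1ccc(F)c(C(=O)Nc2cnc3[nH]c(-c4ccc(Cl)c(Cl)c4)nc3c2)c1F`: in this assay compound 2 gives 2 10^-6 cm/s.

For the measured compounds named here, only two compounds have been measured, and they share everything except the substituted phenyl ring on the fused core. Compound 2 and compound 1 lie within the scatter of each other, as the step of a 1.5-fold higher number from compound 1 to compound 2 (0.19 log units; within the scatter) shows, so on the numbers available the two cannot be told apart.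

Compound 3, `CCCS(=O)(=O)Nc1ccc(F)c(C(=O)Nc2cnc3[nH]c(-c4ccc(C)cc4)nc3c2)c1F`, differs from compound 2 by the change (4-methylphenyl in place of 3,4-dichlorophenyl on an aromatic carbon). Going by the values given here, the only measured step that bears on this change is the one from compound 1 to compound 2, which also swapped the group on that same phenyl ring and stayed within the scatter: a 1.5-fold higher number from compound 1 to compound 2 (0.19 log units; within the scatter). With no measured change at this position reaching beyond the scatter, the expectation for compound 3 is a step of a 1.2-fold lower number from compound 2 to compound 3 (0.07 log units; within the scatter), that is, none that can be distinguished from repeat measurement noise. The estimated value for compound 3 in this assay is therefore 1.7 10^-6 cm/s, with a range from 0.8 10^-6 cm/s to 3.5 10^-6 cm/s.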

Compound 3, apparent permeability: 2.6 10^-6 cm/s
Estimate against measurement, compound 3: 1.5-fold (0.18 log units) below; measured number inside the range.
By their numbers in this assay, from the lowest: compounds 1, 2 and 3 (each within the scatter of the next).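

Compound 1 and compound 2 carry only halogens on the phenyl ring that sits on the carbon between two ring nitrogen atoms, whereas compound 3 carries a methyl on that ring. In this assay there is a 1.3-fold higher number from compound 2 to compound 3 (0.11 log units; within the scatter) and, for methyl in place of bromo, a 2.0-fold higher number from compound 1 to compound 3 (0.30 log units; within the scatter) as well, so replacing the halogens with methyl gives no step beyond the scatter. No measurement shown here accounts for these numbers.

These three compounds cover only halogens and methyl on this one phenyl ring, so they cannot show how far this position tolerates change. As far as these compounds go, whether an amine, a carboxylic acid or a longer chain on that ring would take the number beyond the scatter remains open.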